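Swapping a pyridyl for a methoxyphenyl on the thioether arm

The source may hold more compounds than are shown below. What is called first, only, known or untested is meant among the compounds shown, and "the series" means these compounds.

In an assay on isolated protein for inhibition of Retinaldehyde dehydrogenase 3 (Homo sapiens) (a higher number here means a weaker inhibitor, a lower number a stronger inhibitor), three compounds have been measured:

compound 1 `Cn1ccc2c(=O)n(-c3ccccc3)c(SCc3cccc(F)c3)nc21` gives 600 nM
compound 2 `CC(Sc1nc2c(cnn2C)c(=O)n1-c1ccccc1)c1ccccn1` gives 89 nM
compound 3 `CC(Sc1nc2nn(C3COC3)cc2c(=O)n1-c1ccccc1)c1cccnc1` gives 250 nM

Compound 2 holds the lowest number of the three in this assay, and its gaps to compound 3 and to compound 1 both lie beyond the usual scatter, so it is the strongest inhibitor of this small set. Compound 4 `COc1ccccc1C(C)Sc1nc2c(cnn2C)c(=O)n1-c1ccccc1` has not yet been measured. It differs from compound 2 in one place: 2-methoxyphenyl in place of pyridin-2-yl on a saturated chain carbon bound to a saturated chain carbon and a sulfur. Among the measured compounds shown here, no measured pair in this set shares exactly that change, so the direction of the step rests on nothing firmer than the spread of the numbers already seen, which run from compound 2 upward to compound 1. A step of modest size, toward a higher number, is expected, though a result within the scatter would not surprise. The expected step, a 1.8-fold higher number from compound 2 to compound 4 (0.25 log units; within the scatter), is estimated to be small. For compound 4 the expected value in this assay is 160 nM, with a range from 50 nM to 500 nM.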

Compound 4, half-maximal inhibitory concentration: 112 nM
The estimate for compound 4 lay 1.4-fold (0.15 log units) above the measured number; measured number inside the range.
By their numbers in this assay, from the lowest: compounds 2 and 4 (each within the scatter of the next); then compound 3; then compound 1.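

In this assay, 2-methoxyphenyl in place of pyridin-2-yl on the saturated chain carbon bound to a saturated chain carbon and a sulfur gives a 1.3-fold higher number from compound 2 to compound 4 (0.10 log units; within the scatter). Among the compounds shown here, this is the first pair in the set that differs in one place, and it shows that this position can hold a ring of carbon only, with two more heavy atoms, and keep a number within the scatter of compound 2. In this pair, then, the ring nitrogen of pyridin-2-yl is not needed to hold the number at this level, and nothing measured here accounts for the two groups reading alike.

The compounds shown leave open whether the methoxy group contributes anything, which an unsubstituted phenyl would test. They also leave open how this position would respond to a carboxylic acid or an amine on the ring.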